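The source may hold more compounds than are shown below. What is called first, only, known or untested is meant among the compounds shown, and "the series" means these compounds.

Compound 2 `CC1=C(C)C(=O)c2nn(Cc3ccccc3)nc2C1=O` is one of two compounds that share a core; in a functional assay on KB cells (Homo sapiens) for inhibition, read by colorimetric assay, with a stated time of 72 h (a lower number here means that less compound is needed, a higher number that more compound is needed for the effect), compound 2 gives 3.5 ug/mL. Compound 1 `COC(=O)Cn1nc2c(n1)C(=O)C(C)=C(C)C2=O` carries methoxycarbonyl in place of phenyl on a saturated chain carbon bound to an aromatic nitrogen, and in this assay compound 1 gives 4 ug/mL, so that a 1.1-fold higher number from compound 2 to compound 1 (0.06 log units; within the scatter).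

Compound 3 `Cc1cc2c(cc1C)[n+]([O-])nn2Cc1ccccc1` has a different core; the difference between the two cores is not broken down here. In this assay compound 3 gives > 100 ug/mL, which is a limit of the assay and not a number, as the limit of > 100 ug/mL in this assay, at which 1 of the 3 values shown sits, records.

Compound 4 `COC(=O)Cn1n[n+]([O-])c2cc(C)c(C)cc21` has not been measured in this assay. It stands to compound 3 as compound 1 stands to compound 2, carrying the same change, (methoxycarbonyl in place of phenyl on a saturated chain carbon bound to an aromatic nitrogen). On the core of compound 2 this change left the read-out essentially unmoved, as a 1.1-fold higher number from compound 2 to compound 1 (0.06 log units; within the scatter) shows, and the same flat step is expected here, a step that the limit leaves unreadable from compound 3 to compound 4. Because compound 3 sits at the limit of > 100 ug/mL in this assay, at which 1 of the 3 values shown sits, compound 4 is expected most likely to return only a limit as well, with an estimated value of 150 ug/mL, between 40 ug/mL and 600 ug/mL.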

Compound 4, concentration for half-maximal effect: > 100 ug/mL
Compound 4: no number, only a limit; the forecaster's own chance of this, stated with the estimate: 75%; the middle value does not contradict the limit.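

In this assay compound 4 gives > 100 ug/mL as a limit of the assay and not a number. Among these compounds, no step from compound 3 to compound 4 can be read, as both compounds stand at the same limit: the limit of > 100 ug/mL in this assay, at which 2 of the 4 values shown sit.

The compounds shown leave open whether methoxycarbonyl in place of phenyl moves the read-out at all on the core of compound 3.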